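The compounds below may be only part of what the source reports. "The series", "measured", "known", "first", "only" and "open" are said of these compounds alone.

Measured so far:
compound 1, `CN(C)CCCNc1ccnc2cc(OCc3ccc(F)cc3)ccc12`: 490 nM
compound 2, `Fc1ccc(COc2ccc3c(Cl)ccnc3c2)cc1`: 2780 nM
compound 3, `C=CCOc1ccc2c(NCCCN(C)C)ccnc2c1`: 6680 nM

In a functional assay on BGC-823 cells (Homo sapiens) for cytotoxicity, read by MTT assay, with a stated time of 48 h (a lower number here means a stronger inhibitor, a higher number a weaker inhibitor), compound 1 gives 490 nM, the lowest number of the three. Compound 2 differs from compound 1 in one place: chloro in place of (3-(dimethylamino)propyl)amino on an aromatic carbon. That change made a step of a 5.7-fold higher number from compound 1 to compound 2 (0.75 log units; beyond the scatter). Compound 3 differs from compound 1 at another place: vinyl in place of 4-fluorophenyl on a saturated chain carbon bound to an oxygen on an aromatic ring. That change made a step of a 14-fold higher number from compound 1 to compound 3 (1.13 log units; beyond the scatter), and compound 3 stands highest of the three; of compound 2 and compound 3, compound 3 shows the higher number.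

Compound 4, `C=CCOc1ccc2c(Cl)ccnc2c1`, is not yet measured. It differs from compound 3 as follows: chloro in place of (3-(dimethylamino)propyl)amino on an aromatic carbon. Going by the values given here, this is the same change as the one from compound 1 to compound 2, at the same place, and it occurs twice among the compounds here. The two cores on which it is made differ as described for compound 3 against compound 1, so the change is now made on a core that already carries the higher number.

Among the compounds with values here, for compound 4 a step of a 5.2-fold higher number from compound 3 to compound 4 (0.72 log units; beyond the scatter) is expected, resting on the single earlier instance, the step of a 5.7-fold higher number from compound 1 to compound 2 (0.75 log units; beyond the scatter), with added uncertainty because only one prior example exists and it lies on a different core. Compound 4 is therefore estimated at 35000 nM, with a range from 12000 nM to 100000 nM.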

Compound 4, half-maximal inhibitory concentration: 2930 nM
Compound 4: the middle estimate sits 12-fold (1.08 log units) above what was measured; the measured number lies below the stated range.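

In this assay, chloro in place of (3-(dimethylamino)propyl)amino on the core of compound 3 gives a 2.3-fold lower number from compound 3 to compound 4 (0.36 log units; beyond the scatter), which runs in the opposite direction to the same change on the core of compound 1. In this series the step therefore does not carry from one core to the other, in either size or direction: the same change on two cores in this assay, a 5.7-fold higher number (0.75 log units; beyond the scatter) from compound 1 to compound 2 and a 2.3-fold lower number (0.36 log units; beyond the scatter) from compound 3 to compound 4, 13-fold (1.11 log units) apart, beyond the scatter of two such steps

The two chloro compounds print similar values, with compound 2 at 2780 nM and compound 4 at 2930 nM, but two pairs on two cores give no reason for the reversal and no rule for how the change would behave on a third core.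

Still open, on these data alone, is how other groups on the aromatic carbon opposite the ring nitrogen would behave across these cores, such as a shorter or longer aminoalkyl chain, a piperidine or a simple primary amine. As far as these compounds go, the group on the oxygen is equally open, for example an unsubstituted benzyl, a chlorobenzyl or a longer alkyl chain, and these could show whether the reversal follows the fluorobenzyl group or holds more widely.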